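This account rests on a few compounds, and the source may have more. Where it says the series, first, only, none or still open, it means among the compounds named here.

Working notes on the series. In a functional assay on K562 cells (Homo sapiens) for antiproliferative activity, read by MTT assay, with a stated time of 48 h (on this read-out lower numbers stand for stronger inhibition and higher numbers for weaker inhibition), compound 3 `N#Cc1nc2c(-c3nc4ccccc4[nH]3)c(N)n(CCCN3CCCCC3)c2nc1C#N` gives 3460 nM and compound 1 `CN1CCN(CCn2c(N)c(-c3nc4ccccc4[nH]3)c3nc(C#N)c(C#N)nc32)CC1` gives 6550 nM, two values within the scatter of each other. Compound 2 `CCCCn1c(N)c(-c2nc3ccccc3[nH]2)c2nc(C#N)c(C#N)nc21` gives > 50000 nM, which is a limit and not a number.

Compound 4 `CCN(CC)CCCCn1c(N)c(-c2nc3ccccc3[nH]2)c2nc(C#N)c(C#N)nc21` is not yet measured. Its difference from compound 3 is (diethylamino)methyl in place of piperidin-1-yl on a saturated chain carbon, three bonds along the chain from an aromatic nitrogen; cut one bond further out, this reads 3-(piperidin-1-yl)propyl to 4-(diethylamino)butyl.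

The closest measured precedent is a 1.9-fold lower number from compound 1 to compound 3 (0.28 log units; within the scatter), where one nitrogen-bearing group replaces another and the step stays within the scatter. The two steps that involve the butyl chain are larger and beyond the scatter: an at least 7.6-fold higher number from compound 1 to compound 2 (0.88 log units; beyond the scatter) and an at least 14-fold lower number from compound 2 to compound 3 (1.15 log units; beyond the scatter). Compound 4 keeps a nitrogen-bearing group, so it is not expected to follow compound 2. In this assay, the expected step is a 1.3-fold higher number from compound 3 to compound 4 (0.11 log units; within the scatter), with no change beyond the scatter anticipated in either direction. For compound 4 the estimated value is 4500 nM, with an expected range from 1500 nM to 14000 nM.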

Compound 4, half-maximal inhibitory concentration: 1440 nM
The estimate for compound 4 lay 3.1-fold (0.49 log units) above the measured number; the whole stated range lies above it.
By their numbers in this assay, from the lowest: compound 4; then compounds 3 and 1 (each within the scatter of the next). At a limit, above all of these: compound 2.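

The exchange at this place is not neutral in this assay: a 2.4-fold lower number from compound 3 to compound 4 (0.38 log units; beyond the scatter), although both sides of the exchange carry the same count of heavy atoms and only the enter side lacks a ring. The earlier exchange of one nitrogen-bearing group for another stayed within the scatter, a 1.9-fold lower number from compound 1 to compound 3 (0.28 log units; within the scatter), whereas compound 4 separates from the other amine-bearing compound, a 4.5-fold lower number from compound 1 to compound 4 (0.66 log units; beyond the scatter). On the same butyl chain, adding the diethylamino end gives an at least 34-fold lower number from compound 2 to compound 4 (1.54 log units; beyond the scatter), a step that rests on a limit and not a number: the limit of > 50000 nM in this assay, at which 1 of the 4 values shown sits.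

Chain length and the open or ring form of the amine change together from compound 3 to compound 4, so the step belongs to neither alone. A 4-(piperidin-1-yl)butyl or 3-(diethylamino)propyl group on the shared core would separate the two.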